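Lengthening the Chain of Compound 2 Once More

A few compounds are considered here, and "the series" means these few. Any claim that something is new, unique, unknown or untested is made for them only; others in the source may bear on it.

For the measured compounds named here, in a functional assay on SW480 cells (Homo sapiens) for antiproliferative activity, read by MTT assay, with a stated time of 48 h (on this read-out lower numbers stand for stronger inhibition and higher numbers for weaker inhibition), compound 1 (`CCCCC(CCO)n1cnc2c(Cl)nc(Cl)nc21`) gives 30900 nM, and compound 2 (`CCCCCCC(CCO)n1cnc2c(Cl)nc(Cl)nc21`) gives 12400 nM, the lower of the two actual numbers so far. Compound 3 (`CCCCCCC(CCO)n1cnc2c(N)nc(Cl)nc21`) gives > 50000 nM, which is a limit of the assay and not a number. Compound 4 (`CCCCCCCC(CCO)n1cnc2c(Cl)nc(Cl)nc21`) is unmeasured and differs from compound 2 by methyl in place of hydrogen on a saturated chain carbon, seven bonds along the chain from an aromatic nitrogen. The closest guide is ethyl in place of hydrogen on the same chain, a 2.5-fold lower number from compound 1 to compound 2 (0.40 log units; beyond the scatter). The other step, an at least 4.0-fold higher number from compound 2 to compound 3 (0.60 log units; beyond the scatter), lies elsewhere on the molecule and says little here. Methyl is a smaller addition than ethyl, so a smaller move in the same direction is expected in this assay. The estimated step is a 1.5-fold lower number from compound 2 to compound 4 (0.16 log units; within the scatter). For compound 4 the estimate is 8500 nM, with an expected range of 3500 nM to 20000 nM.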

Compound 4, half-maximal inhibitory concentration: 13600 nM
Compound 4: middle estimate off by 1.6-fold (0.20 log units), on the low side; low and high end bracket the measured number.
By their numbers in this assay, from the lowest: compounds 2 and 4 (each within the scatter of the next); then compound 1. At a limit, above all of these: compound 3.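

In this assay, adding methyl at this place on the chain brings no clear change (a 1.1-fold higher number from compound 2 to compound 4 (0.04 log units; within the scatter)), so the lengthening that helped from compound 1 to compound 2 does not continue to compound 4. The longer chain still keeps its advantage over the shortest chain shown (a 2.3-fold lower number from compound 1 to compound 4 (0.36 log units; beyond the scatter)), which places compound 2 and compound 4 level with each other, both ahead of compound 1. Nothing shown here accounts for this levelling off.

On these data alone, whether a still longer chain would stay level or shift the number remains open. So does the effect of a chain carrying an amine or a carboxylic acid.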